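Side-chain variation on the shared core, compound 4 pending

The source may hold more compounds than are shown below. What is called first, only, known or untested is meant among the compounds shown, and "the series" means these compounds.

Measured so far:
compound 1 `CC(C)(C)OC(=O)NCC1CCCN(C(=O)CN2CN(c3ccccc3)C3(CCN(C(=O)c4ccc(C5CCCCC5)cc4)CC3)C2=O)C1`: 3800 nM
compound 2 `CCc1nn(CC)c(C2CCN(C(=O)CN3CN(c4ccccc4)C4(CCN(C(=O)c5ccc(C(C)(C)C)cc5)CC4)C3=O)CC2)c1C`: 2500 nM
compound 3 `CC(C)(C)c1ccc(C(=O)N2CCC3(CC2)C(=O)N(CC(=O)N2CCC(CCO)CC2)CN3c2ccccc2)cc1`: 2600 nM

In an assay on HEK293 cells for displacement of a labelled ligand from NPC1-like intracellular cholesterol transporter 1 (Homo sapiens) (a lower number here means a stronger inhibitor, a higher number a weaker inhibitor), compound 1 gives the highest of the three numbers, yet its gaps to compound 3 and to compound 2 both fall within the scatter, so the three compounds read as one level. Compound 4 `CCOC(=O)C1CCCN(C(=O)CN2CN(c3ccccc3)C3(CCN(C(=O)c4ccc(C5CCCCC5)cc4)CC3)C2=O)C1` follows from compound 1 by ethoxycarbonyl in place of ((tert-butoxycarbonyl)amino)methyl on a saturated ring carbon.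

Among the compounds with values here, the one measured step that bears on this place is a 1.0-fold higher number from compound 2 to compound 3 (0.02 log units; within the scatter): a large group on a saturated ring carbon replaced by a small one, with no change beyond the scatter. Compounds 1 and 3, which also differ in the group on this part of the core, show numbers within the scatter of each other. Within the data shown here, nothing measured so far suggests that this side chain moves the number.

Compound 4 is therefore expected at about 3500 nM, with a range of 1200 nM to 10000 nM. The expected step is a 1.1-fold lower number from compound 1 to compound 4 (0.04 log units; within the scatter), no change beyond the scatter.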

Compound 4, half-maximal inhibitory concentration: 4200 nM
Beside the measured number, compound 4's estimate is 1.2-fold (0.08 log units) below it; measured number inside the range.
By their numbers in this assay, from the lowest: compounds 2, 3, 1 and 4 (each within the scatter of the next).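

In this assay, the change at this saturated ring carbon, two ring bonds from the ring nitrogen, gives a 1.1-fold higher number from compound 1 to compound 4 (0.04 log units; within the scatter). Ethoxycarbonyl brings 5 heavy atoms and 0 hydrogen-bond donors where ((tert-butoxycarbonyl)amino)methyl has 9 heavy atoms and 1 hydrogen-bond donor, so on the core of compound 1 neither difference comes with a step beyond the scatter at this place. No measurement shown here explains this flat result.

As far as these compounds go, an aminomethyl group with a free amine, a carboxylic acid or a longer alkyl chain at this ring carbon remains open. Also open is whether any group here can separate from this level, since the four compounds shown all lie within the scatter of their neighbours in the order of their numbers.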